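This account rests on a few compounds, and the source may have more. Where it says the series, first, only, none or still open, it means among the compounds named here.

In a functional assay on A549 cells (Homo sapiens) for inhibition, read by sulforhodamine B assay, with a stated time of 74 h (on this read-out higher numbers stand for weaker inhibition and lower numbers for stronger inhibition), compound 1 (`O=C1C=CC2(C=C1)OCC(=O)N2S(=O)(=O)c1ccccc1`) gives > 10000 nM, which is a limit and not a number. Compound 2 (`O=C1C=CC2(C=C1)OCC(=O)N2S(=O)(=O)c1ccc(OC(F)(F)F)cc1`) gives 40 nM. Among the measured compounds shown here, the only measured step, an at least 250-fold lower number from compound 1 to compound 2 (2.39 log units; beyond the scatter), is large and comes from trifluoromethoxy in place of hydrogen on an aromatic carbon. Compound 3 (`O=C1C=CC2(C=C1)OCC(=O)N2S(=O)(=O)c1ccc(Br)s1`) differs from compound 1 by 5-bromothiophen-2-yl in place of phenyl on a sulfonyl sulfur. That measured step involves a different group, so it is only a loose guide, but it points to a large move towards lower numbers in this assay. The expected step is an at least 66-fold lower number from compound 1 to compound 3 (1.82 log units; beyond the scatter). The estimate for compound 3 is 150 nM, within 25 nM to 1500 nM.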

Compound 3, half-maximal inhibitory concentration: 50 nM
Compound 3: middle estimate off by 3.0-fold (0.48 log units), on the high side; measured number inside the range.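

In this assay replacing the phenyl itself on the sulfonyl sulfur, and not only a hydrogen on it, also gives an at least 200-fold lower number from compound 1 to compound 3 (2.30 log units; beyond the scatter). Compound 3 gives 50 nM and compound 2 gives 40 nM, two values within the usual scatter of each other, so two different aromatic groups at this place read alike. The step is only a bound, because compound 1 stands at a limit and not at a number: the limit of > 10000 nM in this assay, at which 1 of the 3 values shown sits.

Open, as far as these compounds go, is how the step divides between the bromine and the five-membered aromatic ring of 5-bromothiophen-2-yl. Also open, from the compounds shown here alone, is how an amine or a carboxylic acid on the aromatic ring would read.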